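The source may report more compounds than this note shows. Statements on the series, on what has been measured and on what is new or still open speak of the compounds shown alone.

Measured compounds:
- compound 1, `COc1ccc(-c2cc3ccccc3nc2/C=C/C(=O)c2ccc(N)cc2)cc1`, 6510 nM
- compound 2, `COc1ccc(-c2cc3ccccc3nc2/C=C/C(=O)c2ccccn2)cc1`, 660 nM
- compound 3, `COc1ccc(-c2cc3ccccc3nc2/C=C/C(=O)c2ccc(Br)s2)cc1`, 710 nM

All three share one core and differ only in the group on the carbonyl carbon. In a functional assay on NCI-H1299 cells (Homo sapiens) for antiproliferative activity, read by XTT assay, with a stated time of 72 h (on this read-out higher numbers stand for weaker inhibition and lower numbers for stronger inhibition), compound 3 stands second of the three numbers; its nearest neighbour is compound 2, with a gap a 1.1-fold higher number from compound 2 to compound 3 (0.03 log units; within the scatter), and the larger gap is a 9.2-fold lower number from compound 1 to compound 3 (0.96 log units; beyond the scatter). The two steps away from compound 1, a 9.9-fold lower number from compound 1 to compound 2 (0.99 log units; beyond the scatter) and a 9.2-fold lower number from compound 1 to compound 3 (0.96 log units; beyond the scatter), are both beyond the scatter and of similar size, whereas the step between the two heteroaryl groups is within it.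

Compound 4, `COc1ccc(-c2cc3ccccc3nc2/C=C/C(=O)c2ccc[nH]2)cc1`, is the next member of this set. The change from compound 3 is 1H-pyrrol-2-yl in place of 5-bromothiophen-2-yl on a carbonyl carbon. For the measured compounds named here, no measured step bears directly on this exchange: the only comparison among five-membered or heteroaryl groups is the one from compound 2 to compound 3, which is flat, while the single donor-bearing group in the set, in compound 1, gives the highest number. On that basis compound 4 is expected to come out somewhat weaker than compound 3, a step of a 2.1-fold higher number from compound 3 to compound 4 (0.32 log units; beyond the scatter) in this assay, though the uncertainty is wide. The estimate for compound 4 is 1500 nM, with a range from 500 nM to 5000 nM.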

Compound 4, half-maximal inhibitory concentration: > 10000 nM
Compound 4 ended at the assay's limit; the forecaster's own chance of this, stated with the estimate: 5%; at least 6.6-fold (0.82 log units) between middle value and limit.
By their numbers in this assay, from the lowest: compounds 2 and 3 (each within the scatter of the next); then compound 1. At a limit, above all of these: compound 4.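

In this assay the value of compound 4 is a limit of the assay and not a number: the limit of > 10000 nM in this assay, at which 1 of the 4 values shown sits. The carbonyl position is not flat among heteroaryl groups: pyridin-2-yl and 5-bromothiophen-2-yl could not be told apart, yet 1H-pyrrol-2-yl, a five-membered aromatic ring like the 5-bromothiophen-2-yl it replaces, gives an at least 14-fold higher number from compound 3 to compound 4 (1.14 log units; beyond the scatter) and, against pyridin-2-yl, an at least 15-fold higher number from compound 2 to compound 4 (1.18 log units; beyond the scatter). The remaining comparison is an at least 1.5-fold higher number from compound 1 to compound 4 (0.18 log units; that floor lies within the scatter), so compound 4 cannot be firmly separated from compound 1, and among these four compounds the two groups carrying a hydrogen-bond donor, 4-aminophenyl and 1H-pyrrol-2-yl, go with the highest numbers, with no compound shown going against this.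

The compounds shown do not separate the arrival of the pyrrole hydrogen from the departure of the bromine and the sulfur, and a 1-methylpyrrol-2-yl group and an unsubstituted thiophen-2-yl group on the carbonyl carbon would bear on that question. Going by these compounds, how far compound 4 lies past its limit also stays open.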